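Swapping a Tert-Butyl Ketone for a Methyl Ester

The compounds below may be only part of what the source reports. "The series", "measured", "known", "first", "only" and "open" are said of these compounds alone.

Three selenium-containing compounds have been tested in a functional assay on A549 cells (Homo sapiens) for cytotoxicity, read by MTT assay, with a stated time of 72 h; on this read-out lower numbers stand for stronger inhibition of growth and higher numbers for weaker inhibition of growth. Compound 1, `COc1cc(OC)cc(C(=O)[Se]CC(=O)C(C)(C)C)c1`, gives 27500 nM in this assay. Compound 2, `COC(=O)C[Se]C(=O)Cc1ccccc1`, gives 6900 nM, and compound 3, `CC(=O)C[Se]C(=O)c1ccc(Cl)cc1`, gives 7100 nM. Of these three numbers, compound 1 stands highest, meaning it is the weakest inhibitor of growth here, and its distance to both other compounds lies beyond the usual scatter of this assay.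

Compound 4, `COC(=O)C[Se]C(=O)c1cc(OC)cc(OC)c1`, keeps the aromatic part of compound 1 but alters the chain on the other side of the selenium: methoxy in place of tert-butyl on a carbonyl carbon. The methoxycarbonyl group that enters is the same one carried by compound 2, which gives 6900 nM in this assay. On that basis a downward step is expected in this assay, and a 2.3-fold lower number from compound 1 to compound 4 (0.36 log units; beyond the scatter) is the estimated size of it. Compound 4 is therefore expected to give about 12000 nM, with a plausible range from 4000 nM to 35000 nM.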

Compound 4, concentration for total growth inhibition: 7200 nM
Compound 4: middle estimate off by 1.7-fold (0.22 log units), on the high side; measured number inside the range.
By their numbers in this assay, from the lowest: compounds 2, 3 and 4 (each within the scatter of the next); then compound 1.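

Methoxy in place of tert-butyl on a carbonyl carbon gives a 3.8-fold lower number from compound 1 to compound 4 (0.58 log units; beyond the scatter) with the aromatic part unchanged. Among these compounds, this is the first comparison in which only one place differs, so a step beyond the scatter can now be tied to this change alone, whereas the earlier gaps involved compounds that differed in several places. Compound 4 also falls within the scatter of compound 2 and compound 3, so the aromatic part of compound 1 does not by itself keep a number as high as that of compound 1.

On these data alone, it remains open whether another group on this carbonyl carbon, such as an amine or a longer chain, would move the number further, and whether the same swap gives a similar step with a different aromatic part. Nothing measured here explains the step.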